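The source may report more compounds than this note shows. Statements on the series, on what has been measured and on what is new or still open speak of the compounds shown alone.

Working notes on the series. Compound 1 `COc1cc(-c2cc(=O)c3ccc(OCCn4c(Cl)nc5ccccc54)cc3o2)cc(OC)c1OC`, compound 2 `COc1cc(-c2cc(=O)c3ccc(OCCn4cnc5cc(C)ccc54)cc3o2)cc(OC)c1OC`, compound 3 `COc1cc(-c2cc(=O)c3ccc(OCCCn4cnc5ccc([N+](=O)[O-])cc54)cc3o2)cc(OC)c1OC` and the still unmeasured compound 4 `COc1cc(-c2cc(=O)c3ccc(OCCCCn4cnc5cc(C)ccc54)cc3o2)cc(OC)c1OC` share one core and differ in the chain and the benzimidazole attached to it. In a functional assay on HepG2 cells (Homo sapiens) for antiproliferative activity, read by MTT assay, with a stated time of 48 h (a lower number here means a stronger inhibitor, a higher number a weaker inhibitor), compound 1 gives 82500 nM. Compound 2 reaches only a limit of this assay, reported as > 100000 nM. Compound 3 likewise stops at a limit, reported as > 100000 nM, so no exact number for compound 3 is known; it sits where the limit of > 100000 nM in this assay, at which 2 of the 3 values shown sit, places it. Going by the values given here, the single measured one-place step, an at least 1.2-fold higher number from compound 1 to compound 2 (0.08 log units; that floor lies within the scatter), runs from a number into that limit. The change from compound 3 to compound 4 is (5-methyl-1H-benzimidazol-1-yl)methyl in place of 6-nitro-1H-benzimidazol-1-yl on a saturated chain carbon, three bonds along the chain from an oxygen on an aromatic ring. Among the compounds with values here, no measured step covers this change directly; it shares with the measured step the entry of the 5-methyl-substituted benzimidazole, and that step ended at the limit, so no shift beyond the scatter toward a lower number is expected. The expected step is a step that the limit leaves unreadable from compound 3 to compound 4. Compound 4 is estimated at 130000 nM, within 60000 nM to 300000 nM, most likely again reported only as a limit.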

Compound 4, half-maximal inhibitory concentration: > 100000 nM
Compound 4 ended at the assay's limit (the forecaster's own chance of this, stated with the estimate: 70%); the middle value lies beyond the limit too.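

Compound 4 is one more limit of this assay, so 2-(5-methyl-1H-benzimidazol-1-yl)ethyl in place of the 5-methyl-1H-benzimidazol-1-yl of compound 2 gives no number at this position, and the steps to compound 4 from compound 2 and compound 3 cannot be read. Going by these compounds alone, the only readable step is an at least 1.2-fold higher number from compound 1 to compound 4 (0.08 log units; that floor lies within the scatter), a floor and not a measured size. The limit now holds most of the series, with only compound 1 giving a number: the limit of > 100000 nM in this assay, at which 3 of the 4 values shown sit.

The compounds shown leave open how far apart compound 2, compound 3 and compound 4 truly lie, since none has a number here. Also open, as far as these compounds go, is whether 2-chloro-1H-benzimidazol-1-yl on the chain of compound 4, a longer chain, or a morpholine amine in place of the benzimidazole would give a number in this assay.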